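Trading a Trifluoroethyl Group for a Vinyl Group

A few compounds are considered here, and "the series" means these few. Any claim that something is new, unique, unknown or untested is made for them only; others in the source may bear on it.

Of the compounds shown here, two sharing one core have been tested in an assay on cells for displacement of a labelled ligand from corticotropin-releasing factor receptor 1 (Homo sapiens), with a stated time of 100 min; on this read-out higher numbers stand for weaker inhibition and lower numbers for stronger inhibition. Compound 1 `CCCN(CC1CC1)C(=O)c1c(C)nc2n(-c3c(C)cc(C)cc3C)c(Cl)cn12` gives 61 nM in this assay. Compound 2 `CCCN(CCC(F)(F)F)Cc1c(C(F)(F)F)nc2n(-c3c(C)cc(C)cc3C)c(Cl)cn12` gives 12 nM in this assay, the lower of the two numbers, with compound 1 sitting at a higher number beyond the usual scatter. These two structures differ in several places at once, so their numbers say nothing about any single change. Compound 3 `C=CCN(CCC)Cc1c(C(F)(F)F)nc2n(-c3c(C)cc(C)cc3C)c(Cl)cn12` has not yet been measured. It differs from compound 2 in one place: vinyl in place of 2,2,2-trifluoroethyl on a saturated chain carbon bound to an amine nitrogen. Within the data shown here, no measured pair shows this change, so the estimated 1.7-fold higher number from compound 2 to compound 3 (0.22 log units; within the scatter) is a small weakening that is expected to stay within the scatter. Compound 3 is expected to give 20 nM, with a likely range from 6 nM to 60 nM.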

Compound 3, inhibition constant: 4.5 nM
Beside the measured number, compound 3's estimate is 4.4-fold (0.65 log units) above it; measured number outside the range, below it.
By their numbers in this assay, from the lowest: compound 3; then compound 2; then compound 1.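

In this assay, putting vinyl in place of 2,2,2-trifluoroethyl on a saturated chain carbon bound to an amine nitrogen gives a 2.7-fold lower number from compound 2 to compound 3 (0.43 log units; beyond the scatter). Among these compounds, this is the first comparison here that isolates a single change, and it shows that this position responds to what it carries and that the fluorine-bearing group is not needed to reach a low number. Nothing measured here accounts for the size or direction of this step.

This single pair cannot separate the loss of the fluorine atoms from the arrival of the double bond, a question that a plain ethyl group in the same place would help to settle. From the compounds shown here alone, how a longer chain, such as a butyl group, or an ether chain would fare at this position also remains open.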